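A few compounds are considered here, and "the series" means these few. Any claim that something is new, unique, unknown or untested is made for them only; others in the source may bear on it.

Measured compounds in the series:
- compound 1, `N=C(N)c1ccc(-c2ccc(-c3cc(Cl)cc(Cl)c3)s2)s1`, 4460 nM
- compound 2, `COc1ccc(-c2ccc(-c3ccc(C(=N)N)o3)o2)cc1`, 5890 nM
- compound 3, `N=C(N)c1ccc(-c2ccc(-c3ccc(Cl)cc3)s2)s1`, 4070 nM

All three numbers come from a functional assay on cells (Panel NCI-60 (60 carcinoma cell lines), Homo sapiens) for inhibition, read by sulforhodamine B assay, with a stated time of 48 h; a lower number here means a stronger inhibitor of growth, a higher number a weaker inhibitor of growth. Compound 2 gives the highest of the three numbers, but its gap to compound 1 and its gap to compound 3 both lie within the scatter, so no ordering among compounds 1, 2 and 3 is supported by these values; the series sits in one narrow band.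

The next compound, compound 4, `N=C(N)c1ccc(-c2ccc(-c3ccccc3)o2)o1`, differs from compound 2 in one place: hydrogen in place of methoxy on an aromatic carbon. Within the data shown here, no step between two measured compounds in this assay isolates such a change, so there is no measured step to copy. The three values in this assay are close to one another despite different substituents on the outer ring, which argues for a step of modest size, in either direction, or none beyond the scatter.

Compound 4 is therefore expected to give about 6500 nM in this assay, with a range from 2500 nM to 16000 nM. The expected step is a 1.1-fold higher number from compound 2 to compound 4 (0.04 log units; within the scatter), estimated as a small loss of growth inhibition at most.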

Compound 4, concentration for total growth inhibition: 6910 nM
Estimate against measurement, compound 4: 1.1-fold (0.03 log units) below; the measured number falls inside the stated range.
By their numbers in this assay, from the lowest: compounds 3, 1, 2 and 4 (each within the scatter of the next).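

In this assay, among these compounds, the replacement of methoxy by hydrogen on an aromatic carbon para to a large group gives a 1.2-fold higher number from compound 2 to compound 4 (0.07 log units; within the scatter), the first measured step that isolates a single change. At this position, the loss of methoxy, with its carbon and its oxygen, therefore produces no difference that can be told from the scatter, and hydrogen keeps compound 4 in the same narrow band as compound 2. Nothing available here bears on the reason for this result.

As far as these compounds go, whether a larger substituent at this position, such as an amine or a carboxylic acid, would also stay within that band remains open. Also open, from the compounds shown here alone, is whether the same change would behave alike on the core of compound 3.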